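A Halogen Swap on the Benzoyl Ring of Compound 1

A few compounds are considered here, and "the series" means these few. Any claim that something is new, unique, unknown or untested is made for them only; others in the source may bear on it.

Compound 1, `O=C(/C(=C\c1ccc(Cl)cc1Cl)S(=O)(=O)c1ccc(Br)cc1)c1ccc(Br)cc1`: 10000 nM
Compound 2, `O=C(/C(=C\c1ccc(F)cc1F)S(=O)(=O)c1ccc(Br)cc1)c1ccc(Br)cc1`: 7500 nM
Compound 3, `O=C(/C(=C\c1c[nH]c2ccccc12)S(=O)(=O)c1ccc(Br)cc1)c1ccc(Br)cc1`: 25000 nM

All three compounds share the same core and were tested in a functional assay on DU-145 cells (Homo sapiens) for inhibition, read by trypan blue exclusion, with a stated time of 96 h; a higher number here means a weaker inhibitor of growth, a lower number a stronger inhibitor of growth. Compound 1 stands second highest of the three numbers. The step of a 1.3-fold lower number from compound 1 to compound 2 (0.12 log units; within the scatter) is within the scatter, so compound 1 and compound 2 cannot be told apart here. The step of a 2.5-fold higher number from compound 1 to compound 3 (0.40 log units; beyond the scatter) is beyond the scatter, and so is a 3.3-fold higher number from compound 2 to compound 3 (0.52 log units; beyond the scatter), which makes compound 3 the weakest growth inhibitor of the three.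

Compound 4, `O=C(/C(=C\c1ccc(Cl)cc1Cl)S(=O)(=O)c1ccc(Br)cc1)c1ccc(Cl)cc1`, has not yet been tested. It differs from compound 1 by chloro in place of bromo on an aromatic carbon, that is, chloro in place of bromo on the carbonyl-bearing ring, while the 2,4-dichlorophenyl on the double-bonded chain carbon stays as it is. Among the compounds with values here, none of the measured steps touches this position: all three vary the group on the double-bonded chain carbon, and they range from within the scatter to modest. A single halogen exchange of this kind gives no reason to expect a step beyond the scatter in this assay in either direction.

Compound 4 is therefore expected to give about 10000 nM, with a likely range of 4000 nM to 25000 nM. The expected step of no change at the digits printed from compound 1 to compound 4 (within the scatter) lies within the scatter.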

Compound 4, concentration for 50% growth inhibition: 50000 nM
Beside the measured number, compound 4's estimate is 5.0-fold (0.70 log units) below it; the measured number lies above the stated range.
By their numbers in this assay, from the lowest: compounds 2 and 1 (each within the scatter of the next); then compounds 3 and 4 (each within the scatter of the next).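

In this assay, chloro in place of bromo on the carbonyl-bearing ring gives a 5.0-fold higher number from compound 1 to compound 4 (0.70 log units; beyond the scatter), with the 2,4-dichlorophenyl group left unchanged. The earlier steps shown here varied only the group on the double-bonded chain carbon, so they could say nothing about this halogen; this step shows that activity in this assay also depends on the group at this second site. The change is small on paper, one heavy atom for one heavy atom, with no ring, hydrogen-bond donor, hydrogen-bond acceptor or net charge entering or leaving, and nothing measured here gives a reason for the loss of growth inhibition.

As far as these compounds go, this is a single exchange at this position, so it remains open whether the same change would carry over to compounds with 2,4-difluorophenyl or 1H-indol-3-yl on the double-bonded chain carbon. From the compounds shown here alone, it also remains open how an amine, a methoxy group or a carboxylic acid would fare in place of the halogen on this ring, and so whether bromo is a special case or just one of several groups that would serve here.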